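This account rests on a few compounds, and the source may have more. Where it says the series, first, only, none or still open, it means among the compounds named here.

Measured so far in an assay on microsomes from liver (strain ICR) for inhibition of acyl-CoA desaturase 1 (Mus musculus), read by scintillation counting, with a stated time of 20 h; on this read-out higher numbers stand for weaker inhibition and lower numbers for stronger inhibition:
- compound 1 `O=C(NCc1nccs1)c1ccc(N2CCN(C(=O)c3ccccc3C(F)(F)F)CC2)nn1`, giving 32 nM
- compound 2 `CC(C(=O)N1CCN(c2ccc(C(=O)NCCC3CC3)nn2)CC1)(C(F)(F)F)C(F)(F)F`, giving 113 nM

Compound 2 stands at the higher of the two numbers in this assay; the gap to compound 1 lies beyond the usual scatter, so compound 2 is the weaker inhibitor of the pair.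

Compound 3 `O=C(NCCC1CC1)c1ccc(N2CCN(C(=O)/C=C\C(F)(F)F)CC2)nn1` has not yet been measured. It differs from compound 2 in one place: 3,3,3-trifluoroprop-1-en-1-yl in place of 1,1-bis(trifluoromethyl)ethyl on a carbonyl carbon. The amide on the other side of the shared core is unchanged. No step between measured compounds touches this position, so the direction of the change is not anchored by any shown pair.

Expectation: the step from compound 2 to compound 3 in this assay is estimated to be small, a 1.3-fold higher number from compound 2 to compound 3 (0.12 log units; within the scatter), within or near the scatter, with a slight lean toward a weaker number. On that basis compound 3 is expected to give about 150 nM, with a range from 40 nM to 600 nM.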

Compound 3, half-maximal inhibitory concentration: > 10000 nM
Compound 3 was reported as a limit; the forecaster's own chance of this, stated with the estimate: 5%; middle value at least 66-fold (1.82 log units) from the limit.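

Working notes on the carbonyl position: this is the first step shown at this position, and it is large. Replacing 1,1-bis(trifluoromethyl)ethyl with 3,3,3-trifluoroprop-1-en-1-yl on a carbonyl carbon, with the amide on the other side unchanged, gives an at least 88-fold higher number from compound 2 to compound 3 (1.94 log units; beyond the scatter). Both groups carry trifluoromethyl, so in this pair a trifluoromethyl group alone does not preserve the inhibition seen for compound 2. In this assay, the result for compound 3 is a limit, not a number: the limit of > 10000 nM in this assay, at which 1 of the 3 values shown sits.

This single step does not separate the role of the double bond from that of the second trifluoromethyl group and the branching. A saturated 3,3,3-trifluoropropyl or a tert-butyl group on this carbonyl carbon would help to tell these apart.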